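Cyano for methylsulfonyl on the benzyl ether of compound 3

This account rests on a few compounds, and the source may have more. Where it says the series, first, only, none or still open, it means among the compounds named here.

In a functional assay on CHOK cells for antagonist activity at growth hormone secretagogue receptor type 1 (Homo sapiens), read by calcium flux (a lower number here means a stronger inhibitor, a higher number a weaker inhibitor), compound 1 `Nc1nc(N)c(-c2ccc(NCc3ccc([N+](=O)[O-])cc3)cc2)c(COCc2ccccc2)n1` gives 5.8 nM and compound 2 `N#Cc1ccc(CNc2ccc(-c3c(N)nc(N)nc3COCc3ccccc3)cc2)cc1` gives 19 nM; the one-point change reads a 3.3-fold higher number from compound 1 to compound 2 (0.52 log units; beyond the scatter). Compound 3 `CS(=O)(=O)c1ccc(COc2ccc(-c3c(N)nc(N)nc3COCc3ccccc3)cc2)cc1` gives 48 nM, the highest of the three numbers, beyond the scatter from both others. Compound 4 `N#Cc1ccc(COc2ccc(-c3c(N)nc(N)nc3COCc3ccccc3)cc2)cc1` differs from compound 3 by cyano in place of methylsulfonyl on an aromatic carbon. Among the compounds with values here, no measured step covers this exact exchange; the step from compound 1 to compound 2 installs the same cyano group and was modest, and compound 2, which carries the cyano group but with a different linker, sits between compound 3 and compound 1. A modest lowering is therefore expected, a 1.6-fold lower number from compound 3 to compound 4 (0.20 log units; within the scatter). For compound 4 the estimate in this assay is 30 nM, with an expected range from 10 nM to 90 nM.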

Compound 4, half-maximal inhibitory concentration: 3610 nM
For compound 4 the middle estimate is 120-fold (2.08 log units) below the measured one; the measured number lies above the stated range.
By their numbers in this assay, from the lowest: compound 1; then compound 2; then compound 3; then compound 4.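

In this assay, within the data shown here, the cyano exchange on the benzyl ether is no modest step like a 3.3-fold higher number from compound 1 to compound 2 (0.52 log units; beyond the scatter) but a large one, a 75-fold higher number from compound 3 to compound 4 (1.88 log units; beyond the scatter). With the nitrile held, (4-cyanobenzyl)oxy in place of (4-cyanobenzyl)amino gives a 190-fold higher number from compound 2 to compound 4 (2.28 log units; beyond the scatter) and the comparison with the nitro amine gives a 620-fold higher number from compound 1 to compound 4 (2.79 log units; beyond the scatter). The ether link alone does not set the loss, since compound 3 carries it and gives 48 nM and stays far lower than compound 4.

No measurement here bears on the cause of this loss. On these data alone, whether methylsulfonyl on the amino link, or a carboxylic acid or primary amide on the ether link, would give a lower number stays open.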